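Sulfonyl aryl variation: from compound 3 to compound 4

The source may hold more compounds than are shown below. What is called first, only, known or untested is meant among the compounds shown, and "the series" means these compounds.

Measured so far:
compound 1 `CC(O)(C(=O)Nc1ccc(S(=O)(=O)c2ccc(F)cc2)cc1)C(F)(F)F` gives 8600 nM
compound 2 `Cc1cccc(S(=O)(=O)c2ccc(NC(=O)C(C)(O)C(F)(F)F)cc2)c1` gives 2200 nM
compound 3 `Cc1ccc(S(=O)(=O)c2ccc(NC(=O)C(C)(O)C(F)(F)F)cc2)cc1` gives > 30000 nM

In a functional assay (Cavia porcellus) with sulfonylurea receptors; K-ATP channels (Homo sapiens) as the target (on this read-out lower numbers stand for stronger inhibition and higher numbers for weaker inhibition), compound 3 returns only a limit, not a number, and it is the one of the three that sits there (the limit of > 30000 nM in this assay, at which 1 of the 3 values shown sits). Compound 1 and compound 2 both give measured numbers, and the two steps leading to compound 3 are in the same direction: an at least 3.4-fold higher number from compound 1 to compound 3 (0.54 log units; beyond the scatter) and an at least 13-fold higher number from compound 2 to compound 3 (1.13 log units; beyond the scatter). Between the two measured numbers the step of a 3.9-fold lower number from compound 1 to compound 2 (0.59 log units; beyond the scatter) is modest.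

Compound 4 `CC(O)(C(=O)Nc1ccc(S(=O)(=O)c2cccnc2)cc1)C(F)(F)F` is the next variation on the sulfonyl sulfur: pyridin-3-yl in place of 4-methylphenyl on a sulfonyl sulfur. The methyl on the aromatic carbon, which marks compound 3 as the weakest reading so far, is gone. Both steps into compound 3 bear on this change, one large and one at least modest, so a step back to a measured number is expected, in the direction of stronger inhibition, of about an at least 3.7-fold lower number from compound 3 to compound 4 (0.57 log units; beyond the scatter). For compound 4 the estimate in this assay is 8000 nM, expected within 2500 nM to 30000 nM.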

Compound 4, half-maximal inhibitory concentration: 3500 nM
Beside the measured number, compound 4's estimate is 2.3-fold (0.36 log units) above it; measured number inside the range.
By their numbers in this assay, from the lowest: compounds 2 and 4 (each within the scatter of the next); then compound 1. At a limit, above all of these: compound 3.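

Compound 3 holds a limit of the assay, not a number: the limit of > 30000 nM in this assay, at which 1 of the 4 values shown sits. With pyridin-3-yl on the sulfonyl sulfur, this assay returns a number again, showing an at least 8.5-fold lower number from compound 3 to compound 4 (0.93 log units; beyond the scatter), and this ring stands level with 3-methylphenyl, with a 1.6-fold higher number from compound 2 to compound 4 (0.20 log units; within the scatter), which lies within the scatter. Against 4-fluorophenyl the same change gives a 2.5-fold lower number from compound 1 to compound 4 (0.39 log units; beyond the scatter), so a ring with a hetero atom is accepted at this position, and the reading is not tied to a methylphenyl group.

The steps shown do not separate the effect of the ring nitrogen from the loss of the methyl, and how a plain phenyl, pyridin-2-yl or pyridin-4-yl would read remains open. Also open, on these data alone, is whether an amine or a carboxylic acid on the pyridin-3-yl ring would keep this reading.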